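Lipophilicity notes on an ethylcarbamate ester series

A few compounds are considered here, and "the series" means these few. Any claim that something is new, unique, unknown or untested is made for them only; others in the source may bear on it.

Measured compounds:
compound 1 `CCNC(=O)OC(C)(C)CCCC(C)C/C=C/C(C)=C/C(=O)OCC` gives 5.65
compound 2 `CCOC(=O)/C=C(C)/C=C/CC(C)CCCC(C)(C)C` gives 7.15
compound 3 `CCNC(=O)OC(C)(C)CCCC(C)C/C=C/C(C)=C/C(=O)OC(C)C` gives 6.06

All three were run in a physicochemical assay for lipophilicity; a higher number here means a more lipophilic compound, a lower number a more polar compound. Compound 4 `CC(/C=C/CC(C)CCCC(C)(C)C)=C\C(=O)OC(C)C` has not yet been run. Compound 4 relates to compound 3 by methyl in place of (ethylcarbamoyl)oxy on a saturated chain carbon bound to three saturated chain carbons, and the same change, (methyl in place of (ethylcarbamoyl)oxy on a saturated chain carbon bound to three saturated chain carbons), separates the measured pair, where it gave a number 1.50 log units higher from compound 1 to compound 2 (beyond the scatter). The place lines of the two changes agree word for word, so this is the same change on a different core. The two cores differ by methyl in place of hydrogen on a saturated chain carbon bound to an oxygen next to a carbonyl group and a saturated chain carbon, which gave a number 0.41 log units higher from compound 1 to compound 3 (beyond the scatter). Compound 3 is expected to move by a number 1.50 log units higher from compound 3 to compound 4 (beyond the scatter) on this assay, because the same change gave a number 1.50 log units higher from compound 1 to compound 2 (beyond the scatter) and the core change is the smaller of the two. Compound 4 is therefore estimated at 7.56, between 7.1 and 8.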

Compound 4, partition coefficient: 7.56
Estimate against measurement, compound 4: no gap at the digits printed, within the range that was stated.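

In this assay, methyl in place of (ethylcarbamoyl)oxy gave a number 1.50 log units higher from compound 3 to compound 4 (beyond the scatter), matching a number 1.50 log units higher from compound 1 to compound 2 (beyond the scatter), so the change carried over at the same size from the core of compound 1 to the core of compound 3. Read the other way, methyl in place of hydrogen gave a number 0.41 log units higher from compound 2 to compound 4 (beyond the scatter), the same size as a number 0.41 log units higher from compound 1 to compound 3 (beyond the scatter), so the two changes add up across these four compounds. This rests on a single pair of cores that differ in one place, so it sets no general rule for the series, and nothing available explains the agreement.

Open, on these data alone, is whether the same change keeps its size on a core carrying a carboxylic acid or an amine. Also open, as far as these compounds go, is where a longer chain on the ester would fall in this assay.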